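Dichlorobenzyl thione series: removal of the methoxy group

A few compounds are considered here, and "the series" means these few. Any claim that something is new, unique, unknown or untested is made for them only; others in the source may bear on it.

Measured so far:
compound 1 `S=c1[nH]ccn1Cc1cc(Cl)ccc1Cl`: 97700 nM
compound 2 `COc1ccc(Cn2cc[nH]c2=S)cc1OC`: 339000 nM
compound 3 `COc1c(Cl)cc(Cn2cc[nH]c2=S)cc1Cl`: 46800 nM

The three compounds share a core carrying a benzyl group, and differ only in what the six-membered aromatic ring bears. In an assay on isolated protein for inhibition of Dopamine beta-hydroxylase (Rattus norvegicus) (a higher number here means a weaker inhibitor, a lower number a stronger inhibitor), compound 3 gives the lowest number of the three. Compound 1 gives a number beyond the scatter above it, and compound 2 stands furthest away, also beyond the scatter. Compound 2, carrying two methoxy groups and no chloro, is the weakest of the set on these numbers; the two chloro-bearing compounds 1 and 3 sit closer together.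

Compound 4 `S=c1[nH]ccn1Cc1cc(Cl)cc(Cl)c1` has not yet been measured. It differs from compound 3 by hydrogen in place of methoxy on an aromatic carbon. The place is on an aromatic carbon ortho to two chloro groups and para to the group of 7 heavy atoms that carries the core.

Within the data shown here, no pair of measured compounds differs in one place alone, so the weight of the methoxy group on its own is not known from these data. What is seen is that compounds 1 and 3, both bearing two chloro groups, give numbers not far apart, while compound 2 without chloro lies well above. The chloro groups are retained in compound 4; the methoxy is lost. The expected step of a 1.6-fold higher number from compound 3 to compound 4 (0.20 log units; within the scatter) from compound 3 to compound 4 is therefore small, in the direction of a weaker inhibitor, and may fall within the scatter. Compound 4 is estimated at 75000 nM, with a range of 25000 nM to 220000 nM.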

Compound 4, half-maximal inhibitory concentration: 2400 nM
The estimate for compound 4 lay 31-fold (1.49 log units) above the measured number; the whole stated range lies above it.
By their numbers in this assay, from the lowest: compound 4; then compound 3; then compound 1; then compound 2.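

In this assay, among these compounds, hydrogen in place of methoxy on the aromatic carbon ortho to two chloro groups gives a 20-fold lower number from compound 3 to compound 4 (1.29 log units; beyond the scatter) and is the first change that can be read at a single place. With both chloro groups retained, compound 3 stands at 46800 nM and compound 4 at 2400 nM, so this position is far from indifferent, and the methoxy group is clearly not tolerated here as well as hydrogen. The data at hand offer no measurement that would explain the size of this step.

Open, as far as these compounds go, is how other groups at this same aromatic carbon would compare with hydrogen and methoxy, for example hydroxy, fluoro, an amine, a carboxylic acid or a longer alkoxy chain. Also open is whether a step of this size from methoxy to hydrogen carries over to a ring without the two chloro groups, since the compounds shown hold only this one pair.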